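Methyl Placement on the Benzyl Group: Outlook for Compound 3

The source may hold more compounds than are shown below. What is called first, only, known or untested is meant among the compounds shown, and "the series" means these compounds.

Measured so far:
compound 1, `O=C(NC1CCN(Cc2ccc(Cl)cc2)CC1)c1ccc2ccccc2c1`, 37 nM
compound 2, `Cc1ccccc1CN1CCC(NC(=O)c2ccc3ccccc3c2)CC1`, 26 nM

In an assay on isolated protein for displacement of a labelled ligand from D(4) dopamine receptor (Homo sapiens) (a lower number here means a stronger inhibitor, a higher number a weaker inhibitor), compound 1 gives 37 nM, and compound 2 gives 26 nM. Within the data shown here, the one measured step, a 1.4-fold lower number from compound 1 to compound 2 (0.15 log units; within the scatter), falls within the scatter, so compound 2 stands at the lower of the two numbers without being separable from compound 1.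

Compound 3, `Cc1ccc(CN2CCC(NC(=O)c3ccc4ccccc4c3)CC2)cc1`, is the next member. It differs from compound 2 by 4-methylphenyl in place of 2-methylphenyl on a saturated chain carbon bound to an amine nitrogen in a ring. Among the measured compounds shown here, no measured step tests this exact change. For the measured compounds named here, the only step available, a 1.4-fold lower number from compound 1 to compound 2 (0.15 log units; within the scatter), shows that exchanging the whole aryl group at this position, from 4-chlorophenyl to 2-methylphenyl, left the number within the scatter. Moving the methyl on that same aryl group is a smaller change than that exchange, so no step beyond the scatter is expected in this assay, in either direction.

Compound 3 is therefore estimated at 30 nM, with a range from 12 nM to 75 nM, the expected step being a 1.2-fold higher number from compound 2 to compound 3 (0.06 log units; within the scatter).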

Compound 3, inhibition constant: 21 nM
For compound 3 the middle estimate is 1.4-fold (0.15 log units) above the measured one; low and high end bracket the measured number.
By their numbers in this assay, from the lowest: compounds 3, 2 and 1 (each within the scatter of the next).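

In this assay, among these compounds, moving the methyl around the ring, 2-methylbenzyl to 4-methylbenzyl, gives a 1.2-fold lower number from compound 2 to compound 3 (0.09 log units; within the scatter) and is the first direct test of methyl placement at this position; the two placements cannot be told apart. The pair of compound 1 and compound 3 adds a cleaner comparison than the earlier step, which exchanged the substituent and its placement together: methyl in place of chloro on an aromatic carbon gives a 1.8-fold lower number from compound 1 to compound 3 (0.25 log units; within the scatter) and can also not be told apart in this assay. All three compounds now sit within the scatter of one another, so neither the identity of these two substituents nor the methyl placement shows a measurable effect on the number here, and no measurement is available that could account for this.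

As far as these compounds go, it remains open whether the number would stay in this range with a carboxylic acid or an amine in place of the methyl, or with a longer chain on the amine nitrogen in the ring. The rest of the shared core is identical in all three compounds, so these results say nothing about changes there.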